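Swapping a furan for a chlorothiophene on a ketone core

The source may report more compounds than this note shows. Statements on the series, on what has been measured and on what is new or still open speak of the compounds shown alone.

Of the compounds shown here, three sharing one core have been tested in an assay for inhibition of Maternal embryonic leucine zipper kinase (Homo sapiens), read by ADP-Glo, with a stated time of 0.5 h; a lower number here means a stronger inhibitor, a higher number a weaker inhibitor. Compound 1 `COc1ccc(C(=O)c2sc(NC(C)C)c(C#N)c2N)cc1` gives 4130 nM. Compound 3 `CC(C)Nc1sc(C(=O)c2ccco2)c(N)c1C#N` gives 1350 nM, the lowest of the two plain numbers, with compound 1 the nearest to it. Compound 2 `CC(C)Nc1sc(C(=O)c2ccc(C#N)cc2)c(N)c1C#N` gives > 5000 nM, which is a limit of the assay rather than a number. Among the compounds with values here, the only measured step, an at least 1.2-fold higher number from compound 1 to compound 2 (0.08 log units; that floor lies within the scatter), alters a group on the aromatic ring attached to the carbonyl, and its size rests on a floor (the limit of > 5000 nM in this assay, at which 1 of the 3 values shown sits). Compound 4 `CC(C)Nc1sc(C(=O)c2cc(Cl)cs2)c(N)c1C#N` differs from compound 3 in 4-chlorothiophen-2-yl in place of furan-2-yl on a carbonyl carbon, an exchange of the whole ring, so that measured step offers little guidance. The expected step is a 1.4-fold lower number from compound 3 to compound 4 (0.13 log units; within the scatter), close to no change beyond the scatter. Compound 4 is estimated at 1000 nM, between 300 nM and 4000 nM.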

Compound 4, half-maximal inhibitory concentration: 575 nM
For compound 4 the middle estimate is 1.7-fold (0.24 log units) above the measured one; low and high end bracket the measured number.
By their numbers in this assay, from the lowest: compound 4; then compound 3; then compound 1. At a limit, above all of these: compound 2.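

Within the data shown here, exchanging the whole ring on the carbonyl carbon gives the first step at this position whose size is a true measured difference beyond the scatter: a 2.3-fold lower number from compound 3 to compound 4 (0.37 log units; beyond the scatter). The entering ring brings sulfur and chlorine together, so this single step cannot say which of the two matters. Nothing shown here explains the change.

On these data alone, the effect of the chlorine alone remains open, and a plain thiophen-2-yl would address it. As far as these compounds go, it is also open how this position responds to a ring carrying an amine or a carboxylic acid.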